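The source may hold more compounds than are shown below. What is called first, only, known or untested is meant among the compounds shown, and "the series" means these compounds.

Measured compounds:
compound 1 `O=C(NCc1ccc(F)cc1)c1nc(Br)c2cccnc2c1NCc1ccccc1` — "not determined" (no result reported) in a functional assay on MCF7 cells (Homo sapiens) for cytotoxicity, read by MTT assay, with a stated time of 72 h; on this read-out higher numbers stand for weaker inhibition and lower numbers for stronger inhibition
compound 2 `N[C@H]1CC[C@H](Nc2c(C(=O)NCc3ccc(Cl)cc3)nc(Br)c3cccnc23)CC1` — "not determined" (no result reported)
compound 3 `N[C@H]1CC[C@H](Nc2c(C(=O)NCc3ccc(Oc4ccccc4)cc3)nc(Br)c3cccnc23)CC1` — 7900 nM

Compound 1 stands without a number: in this assay compound 1 gives "not determined" (no result reported), and compound 2 likewise gives "not determined" (no result reported). Among the measured compounds shown here, the only reported value on the shared core belongs to compound 3, which in this assay gives 7900 nM. For the measured compounds named here, no pair of measured compounds differs in a single place, so no sized step exists among them.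

The piece follows the change from compound 1 to compound 4 `Nc1ccc(Nc2c(C(=O)NCc3ccc(F)cc3)nc(Br)c3cccnc23)cc1`. The difference is counted as 4-aminophenyl in place of benzyl on a nitrogen on an aromatic ring. Because compound 1 gives "not determined" (no result reported), the step cannot be sized from the numbers, and no direction beyond the usual scatter of this assay can be asserted for it.

Compound 4 is expected to fall in this assay at about 8000 nM, within a range from 2000 nM to 30000 nM. Going by the values given here, this expectation rests on compound 3, whose value of 7900 nM is the only number available on this core, and it carries wide uncertainty since compound 4 shares neither its amide substituent nor its amine substituent.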

Compound 4, half-maximal inhibitory concentration: 4000 nM
For compound 4 the middle estimate is 2.0-fold (0.30 log units) above the measured one, and the stated range covers the measured number.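

Among the compounds shown here, compound 4 gives 4000 nM in this assay while compound 1 gives "not determined" (no result reported) there, so no step between compound 1 and compound 4 can be read. The compounds shown leave open what 4-aminophenyl in place of benzyl on that nitrogen does to the read-out. Nothing shown offers an explanation for the value of compound 4.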